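This account rests on a few compounds, and the source may have more. Where it says the series, first, only, none or still open, it means among the compounds named here.

Measured so far:
Compound 1, `COc1cc(-c2nnc3n2NC(c2ccco2)C(C(=O)c2ccccc2C)S3)cc(OC)c1OC`: 63000 nM
Compound 2, `COc1cc(-c2nnc3n2NC(c2ccco2)C(C(=O)c2ccc([N+](=O)[O-])cc2)S3)cc(OC)c1OC`: 87800 nM

Both numbers come from a functional assay on HepG2 cells (Homo sapiens) for cytotoxicity, read by MTT assay, with a stated time of 48 h; a lower number here means a stronger inhibitor, a higher number a weaker inhibitor. Among the measured compounds shown here, compound 2 has the nearest neighbour in compound 1, and the only measured step, a 1.4-fold higher number from compound 1 to compound 2 (0.14 log units; within the scatter), exchanges one aryl group on the carbonyl carbon for another without moving the number beyond the scatter. The two values therefore cannot be ordered against each other.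

Compound 3, `COc1cc(-c2nnc3n2NC(c2ccco2)C(C(=O)c2ccc(-c4ccccc4)cc2)S3)cc(OC)c1OC`, is not yet measured. It differs from compound 2 by phenyl in place of nitro on an aromatic carbon, so the aryl group on the carbonyl carbon changes from 4-nitrophenyl to 4-phenylphenyl, the new group sitting on an aromatic carbon of the six-membered ring, para to a large group. For the measured compounds named here, the one step that bears on this is a 1.4-fold higher number from compound 1 to compound 2 (0.14 log units; within the scatter), where a change of the same aryl group left this assay essentially unmoved. On that basis the step of a 1.1-fold lower number from compound 2 to compound 3 (0.04 log units; within the scatter) is expected to stay within the scatter, with no clear direction. Compound 3 is accordingly estimated at 80000 nM, with a range from 30000 nM to 200000 nM.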

Compound 3, half-maximal inhibitory concentration: > 100000 nM
Compound 3 ended at the assay's limit (the forecaster's own chance of this, stated with the estimate: 20%); middle value at least 1.2-fold (0.09 log units) away from the limit.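

In this assay compound 3 gives > 100000 nM, which is a limit of the assay and not a number: the limit of > 100000 nM in this assay, at which 1 of the 3 values shown sits.

The two new steps are therefore floors rather than measured sizes: an at least 1.1-fold higher number from compound 2 to compound 3 (0.05 log units; that floor lies within the scatter) and an at least 1.5-fold higher number from compound 1 to compound 3 (0.20 log units; that floor lies within the scatter) only say how far the number has risen at minimum, and the true distance could be small or much larger. Among the compounds shown here, what this adds to the earlier pair is that replacing nitro with phenyl, on an aromatic carbon para to a large group, gives the first compound here without a readable number, and the 4-phenylphenyl group shows no sign of bringing the number down.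

The compounds shown leave open how an amine or a carboxylic acid at this same place would read in this assay, and whether any group there could give a clearly lower number. For the compounds shown here, no step printed so far lies beyond the scatter, so the aryl group on the carbonyl carbon has not yet been tied to any firm change in this cell test.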